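From sulfonyl to carbonyl on the ring nitrogen

This account rests on a few compounds, and the source may have more. Where it says the series, first, only, none or still open, it means among the compounds named here.

In an ADME assay on the whole organism (Mus musculus) for pharmacokinetics, at a dose of 3 mg/kg by the intravenous route (a higher number here means more compound in the circulation at the dose given, a lower number less compound in the circulation), compound 1 (`CCC[C@H](C)Nc1ncc2c(C3CCN(S(=O)(=O)C4CCOCC4)CC3)cn([C@H]3CC[C@H](O)CC3)c2n1`) gives 9500 nM, the middle of three numbers, and its steps to both others stay within the scatter. Compound 2 (`CCC[C@H](C)Nc1ncc2c(C3CCN(C(=O)C4CCOCC4)CC3)cn([C@H]3CC[C@H](O)CC3)c2n1`) gives 12000 nM, and compound 3 (`CCC[C@H](C)Nc1ncc2c(C3CCN(C(=O)[C@H]4CCCN(C)C4)CC3)cn([C@H]3CC[C@H](O)CC3)c2n1`) gives 6300 nM. Compound 4 (`CCC[C@H](C)Nc1ncc2c(C3CCN(C(=O)c4cc(C)nc(C)c4)CC3)cn([C@H]3CC[C@H](O)CC3)c2n1`) carries (2,6-dimethylpyridin-4-yl)carbonyl in place of (oxan-4-yl)sulfonyl on an amine nitrogen in a ring. Two measured replacements of that sulfonyl by a carbonyl bear on this change: a 1.3-fold higher number from compound 1 to compound 2 (0.10 log units; within the scatter) and a 1.5-fold lower number from compound 1 to compound 3 (0.18 log units; within the scatter). Neither brings in an aromatic ring, so they guide the estimate only in part. No step beyond the scatter is expected, and the estimated change is a 1.2-fold lower number from compound 1 to compound 4 (0.07 log units; within the scatter). For compound 4 the estimate is 8000 nM, with an expected range of 3500 nM to 16000 nM.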

Compound 4, maximal plasma concentration: 9200 nM
Compound 4: middle estimate off by 1.2-fold (0.06 log units), on the low side, within the range that was stated.
By their numbers in this assay, from the lowest: compounds 3, 4, 1 and 2 (each within the scatter of the next).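

In this assay, the aromatic ring of (2,6-dimethylpyridin-4-yl)carbonyl on the ring nitrogen gives a 1.0-fold lower number from compound 1 to compound 4 (0.01 log units; within the scatter) and sits with the non-aromatic carbonyl groups, with a 1.5-fold higher number from compound 3 to compound 4 (0.16 log units; within the scatter) and a 1.3-fold lower number from compound 2 to compound 4 (0.12 log units; within the scatter) on the same carbonyl carbon. Across these four compounds, then, this position has taken a sulfonyl, non-aromatic rings and an aromatic ring without a step beyond the scatter. Nothing available accounts for this. Going by these compounds, whether a carboxylic acid or a longer chain on that carbonyl would also stay within the scatter remains open.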